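Methoxy in Place of Chloro: A Modest Loss Expected

The source may report more compounds than this note shows. Statements on the series, on what has been measured and on what is new or still open speak of the compounds shown alone.

Compound 1 `NC(=O)c1c(NC(=O)c2ccccc2I)sc2c1CCN(C(=S)Nc1ccccc1Cl)C2` gives 8560 nM in a functional assay on HL-60 cells (Homo sapiens) for antiproliferative activity, with a stated time of 24 h; a higher number here means a weaker inhibitor, a lower number a stronger inhibitor.
Compound 2 `COc1ccccc1C(=O)Nc1sc2c(c1C(N)=O)CCN(C(=S)Nc1ccccc1Cl)C2` gives 20800 nM in this assay.

Compound 1 holds the lowest number of the two measured compounds in this assay. Among the measured compounds shown here, the only measured step, a 2.4-fold higher number from compound 1 to compound 2 (0.39 log units; beyond the scatter), arose from methoxy in place of iodo on a different ring. Compound 3 `COc1ccccc1NC(=S)N1CCc2c(sc(NC(=O)c3ccccc3I)c2C(N)=O)C1` differs from compound 1 by methoxy in place of chloro on an aromatic carbon. That measured step bears on it only loosely, since a halogen is again replaced by methoxy, so a rise of similar or smaller size is expected rather than none. Compound 3 is therefore estimated at 14000 nM in this assay, between 6000 nM and 35000 nM, which means an expected step of a 1.6-fold higher number from compound 1 to compound 3 (0.21 log units; within the scatter).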

Compound 3, half-maximal inhibitory concentration: > 50000 nM
Compound 3: only a limit was reported; the forecaster's own chance of this, stated with the estimate: 10%; at least 3.5-fold (0.55 log units) between middle value and limit.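

In this assay, changing 2-chlorophenyl to 2-methoxyphenyl gives an at least 5.8-fold higher number from compound 1 to compound 3 (0.76 log units; beyond the scatter), so the group on this aromatic carbon clearly matters. That step is larger than the earlier methoxy change on the other ring, a 2.4-fold higher number from compound 1 to compound 2 (0.39 log units; beyond the scatter), so the same kind of swap need not cost the same in each place. The reading for compound 3 is a limit of the assay, not a number: the limit of > 50000 nM in this assay, at which 1 of the 3 values shown sits.

From the compounds shown here alone, how large the true step is remains open. Going by these compounds, it is also open whether losing chloro or gaining methoxy drives the change, a question that fluoro, methyl or an amine on the same aromatic carbon would bear on.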